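Five- to Six-Membered Amine Ring at the Chain End

The source may hold more compounds than are shown below. What is called first, only, known or untested is meant among the compounds shown, and "the series" means these compounds.

Of the compounds shown here, three built on one shared core have been measured in a functional assay on HT-29 cells (Homo sapiens) for cytotoxicity, read by MTT assay, with a stated time of 72 h; a lower number here means a stronger inhibitor, a higher number a weaker inhibitor. Compound 1 `COc1cc2c(Oc3ccc(NC(=O)c4cc(-c5ccccc5F)ccn4)cc3F)ccnc2cc1OCCCN1CCCCC1` gives 320 nM. Going by the values given here, compound 2 `COc1ccc(-c2ccnc(C(=O)Nc3ccc(Oc4ccnc5cc(OCCCN6CCCCC6)c(OC)cc45)c(F)c3)c2)cc1` gives 690 nM; the single change between these two is a 2.2-fold higher number from compound 1 to compound 2 (0.33 log units; beyond the scatter). Compound 3 `COc1cc2c(Oc3ccc(NC(=O)c4cc(-c5ccccc5)ccn4)cc3F)ccnc2cc1OCCCN1CCCC1` gives 120 nM, the lowest of the three numbers, and its gap to compound 1, and the wider gap to compound 2, both lie beyond the usual scatter, so compound 3 is the most potent of the measured set.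

Compound 4 `COc1cc2c(Oc3ccc(NC(=O)c4cc(-c5ccccc5)ccn4)cc3F)ccnc2cc1OCCCN1CCCCC1` has not yet been tested. It differs from compound 3 by piperidin-1-yl in place of pyrrolidin-1-yl on a saturated chain carbon, three bonds along the chain from an oxygen on an aromatic ring. Among the compounds with values here, none of the measured steps touches this part of the molecule: the only step available, between compound 1 and compound 2, changes an aromatic group elsewhere. With no direct guide, the expected step in this assay is a 1.5-fold higher number from compound 3 to compound 4 (0.18 log units; within the scatter), that is, nothing beyond the scatter. Compound 4 is therefore expected to give about 180 nM in this assay, estimated between 70 nM and 500 nM.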

Compound 4, half-maximal inhibitory concentration: 270 nM
Beside the measured number, compound 4's estimate is 1.5-fold (0.18 log units) below it, within the range that was stated.
By their numbers in this assay, from the lowest: compound 3; then compounds 4 and 1 (each within the scatter of the next); then compound 2.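

Going by these compounds alone, this is the first look at the amine ring at the chain end, and in this assay its size registers: swapping pyrrolidin-1-yl for piperidin-1-yl gives a 2.3-fold higher number from compound 3 to compound 4 (0.35 log units; beyond the scatter), a modest step beyond the scatter. On the aromatic group at the other end of the molecule, replacing methoxy with hydrogen gives a 2.6-fold lower number from compound 2 to compound 4 (0.41 log units; beyond the scatter), whereas replacing fluoro with hydrogen gives only a 1.2-fold lower number from compound 1 to compound 4 (0.07 log units; within the scatter), which is within the scatter. No measurement here explains why the ring size changes the number.

Within the data shown here, only one pair of compounds compares the two rings, so it remains open whether the step would be the same with 2-fluorophenyl or 4-methoxyphenyl in place of phenyl. Going by these compounds, how a morpholine ring, an open-chain dimethylamino group or a longer chain would behave at this position also remains open.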